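Moving a Methoxy Pattern Across Two Flipped Cores

This account rests on a few compounds, and the source may have more. Where it says the series, first, only, none or still open, it means among the compounds named here.

Compound 1, `COc1ccc(/C=C/C(=O)c2ccccc2-c2ccc(F)cc2)cc1`, was tested in a functional assay on MCF7 cells (Homo sapiens) for antiproliferative activity, read by sulforhodamine B assay, with a stated time of 48 h (on this read-out lower numbers stand for stronger inhibition and higher numbers for weaker inhibition), and gives 670 nM. Compound 2, `COc1ccc(/C=C/C(=O)c2ccccc2-c2ccc(F)cc2)cc1OC`, carries one more substituent: methoxy in place of hydrogen on an aromatic carbon. In this assay compound 2 gives 240 nM, and that change produced a 2.8-fold lower number from compound 1 to compound 2 (0.45 log units; beyond the scatter). Compound 3, `COc1ccc(C(=O)/C=C/c2ccccc2-c2ccc(F)cc2)cc1`, has the same atoms as compound 1 joined differently; the difference between the two cores is not broken down here. In this assay compound 3 gives 8800 nM, the highest number among the three measured. Compound 4, `COc1ccc(C(=O)/C=C/c2ccccc2-c2ccc(F)cc2)cc1OC`, stands to compound 3 as compound 2 stands to compound 1: methoxy in place of hydrogen on an aromatic carbon. The surroundings of the new group are the same in both pairs, so the same change is expected to act alike, and the expected step is a 2.8-fold lower number from compound 3 to compound 4 (0.44 log units; beyond the scatter), resting on a 2.8-fold lower number from compound 1 to compound 2 (0.45 log units; beyond the scatter). Compound 4 is therefore estimated at 3200 nM, with a likely range from 1200 nM to 8000 nM.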

Compound 4, half-maximal inhibitory concentration: 7100 nM
The estimate for compound 4 lay 2.2-fold (0.35 log units) below the measured number; the range from low to high includes it.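

In this assay, adding the methoxy group to the core of compound 3 gives a 1.2-fold lower number from compound 3 to compound 4 (0.09 log units; within the scatter), so on this core the added group has no effect that can be told apart from the scatter. Set beside the earlier step, the two results still do not differ by more than the scatter allows: the same change on two cores in this assay, a 2.8-fold lower number (0.45 log units; beyond the scatter) from compound 1 to compound 2 and a 1.2-fold lower number (0.09 log units; within the scatter) from compound 3 to compound 4, 2.3-fold (0.35 log units) apart, within the scatter of two such steps. Within the data shown here, this shows no measurable difference in how the change acts on the two cores, but it does not prove that the change acts alike, as it rests on one pair per core and only the step on the core of compound 1 is clear.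

The compounds shown leave open how other groups in the same place, such as a hydroxyl, an ethoxy or an amine, would carry from one core to the other.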